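This account rests on a few compounds, and the source may have more. Where it says the series, first, only, none or still open, it means among the compounds named here.

Compound 3 `O=C1CNC(=O)N1C[C@H]1CN(c2ccc(-n3cc(-c4ccccn4)cn3)c(F)c2)C(=O)O1` sits at the top of what an ADME assay on L02 cells (Homo sapiens) for cytotoxicity, read by MTT assay, with a stated time of 48 h (on this read-out lower numbers stand for stronger inhibition and higher numbers for weaker inhibition), can report: in this assay compound 3 gives only a limit, > 400 ug/mL. Compound 2 `CN(CCC#N)C[C@H]1CN(c2ccc(-n3cc(-c4ccccn4)cn3)c(F)c2)C(=O)O1` likewise gives only a limit in this assay, > 400 ug/mL. Compound 1 `O=C1O[C@@H](CO)CN1c1ccc(-n2cc(-c3ccccn3)cn2)c(F)c1` alone gives a number in this assay, 59 ug/mL. Of the measured steps, an at least 6.7-fold higher number from compound 1 to compound 2 (0.83 log units; beyond the scatter) and an at least 6.7-fold higher number from compound 1 to compound 3 (0.83 log units; beyond the scatter) both climb out of the readable range, and a step that the two limits leave unreadable from compound 2 to compound 3. Both enlargements from compound 1 end at the limit of > 400 ug/mL in this assay, at which 2 of the 3 values shown sit, so their true size is hidden. Compound 4 `O=C(OC[C@H]1CN(c2ccc(-n3cc(-c4ccccn4)cn3)c(F)c2)C(=O)O1)c1ccccc1` differs from compound 3 in one place: benzoyloxy in place of 2,5-dioxoimidazolidin-1-yl on a saturated chain carbon bound to a saturated ring carbon. Among the measured compounds shown here, no measured step sets a benzoyloxy group against the hydantoin, so the expectation rests on the two enlargements from compound 1, both of which lifted the value beyond reach. Compound 4 is expected to give a value near 200 ug/mL, between 60 ug/mL and 400 ug/mL. For compound 4 this is estimated to mean an at least 2.0-fold lower number from compound 3 to compound 4 (0.30 log units; that floor lies within the scatter).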

Compound 4, half-maximal inhibitory concentration: > 400 ug/mL
Compound 4: a limit, no number; the forecaster's own chance of this, stated with the estimate: 45%; at least 2.0-fold (0.30 log units) between middle value and limit.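

In this assay, benzoyl in place of hydrogen on an oxygen on a saturated carbon gives an at least 6.7-fold higher number from compound 1 to compound 4 (0.83 log units; beyond the scatter), so a replacement that keeps the oxygen and brings a six-membered aromatic ring of carbon only, with no nitrogen, ends as the two nitrogen-bearing replacements did. Compound 4 gives a limit, > 400 ug/mL, not a number. The steps among compound 2, compound 3 and compound 4 cannot be read, so these three replacements of the hydroxy group cannot be ranked, and all that can be said is that they end alike: the limit of > 400 ug/mL in this assay, at which 3 of the 4 values shown sit.

The true size of each step from compound 1 stays hidden. Also open, on these data alone, is whether a methoxy group, an acetoxy group or a primary amine at this position would give a readable number in this assay.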